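Swapping the Amino Link of Compound 1 for Phenoxy

The source may hold more compounds than are shown below. What is called first, only, known or untested is meant among the compounds shown, and "the series" means these compounds.

Compound 1 `CC1(C)Oc2ccc(C#N)cc2[C@@H](/N=C(\NC#N)Nc2ccc(Cl)cc2)[C@@H]1O` is the starting point here. In a functional assay (aorta) with Rattus norvegicus as the target (on this read-out lower numbers stand for stronger inhibition and higher numbers for weaker inhibition), compound 1 gives 1800 nM. Among the compounds with values here, its only measured neighbour is compound 2 `CC1(C)Oc2ccc(C#N)cc2[C@@H](/N=C(\NC#N)Nc2ccccc2)[C@@H]1O`, and in this assay compound 2 gives 1400 nM; 1300 nM (2 entries). The repeat measurements, (the several entries of compound 2 in this assay, 1400 nM; 1300 nM (2 entries)), agree closely. The values of these two compounds lie within the usual scatter of each other, so neither can be ranked above the other.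

Compound 3 `CC1(C)Oc2ccc(C#N)cc2[C@@H](/N=C(\NC#N)Oc2ccccc2)[C@@H]1O` has not yet been measured. It keeps the shared core, but phenoxy takes the place of (4-chlorophenyl)amino on a carbon with a double bond to nitrogen: phenoxy in place of (4-chlorophenyl)amino on a carbon with a double bond to nitrogen. Within the data shown here, no measured pair shows what this kind of exchange does, so the expectation is loose and the range is wide. Among the measured compounds shown here, the only guide is that compound 1 at 1800 nM and compound 2 at 1400 nM; 1300 nM (2 entries) sit close together. No change beyond the scatter is expected in this assay, in either direction. The expected step is a 1.2-fold lower number from compound 1 to compound 3 (0.08 log units; within the scatter). For compound 3 the estimated value is 1500 nM, with an expected range from 450 nM to 5000 nM.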

Compound 3, half-maximal inhibitory concentration: > 100000 nM
Compound 3 ended at the assay's limit; the forecaster's own chance of this, stated with the estimate: 15%; at least 66-fold (1.82 log units) between middle value and limit.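

The exchange at this carbon with a double bond to nitrogen gives an at least 55-fold higher number from compound 1 to compound 3 (1.74 log units; beyond the scatter) in this assay, so this place tolerates far less than the earlier pair suggested, where compound 1 and compound 2 could not be ranked. Compound 3 carries the same plain phenyl ring as compound 2, which gives 1400 nM; 1300 nM (2 entries), so the missing chlorine does not account for the gap; what separates these two is the amino link against the oxygen link, and the hydrogen-bond donor counted on the leaving group goes with it. For compound 3, > 100000 nM is a limit of the assay and not a number, so the full size of the step cannot be read: the limit of > 100000 nM in this assay, at which 1 of the 3 values shown sits.

The compounds shown leave open whether the drop goes with the loss of the hydrogen on the link or with the arrival of the oxygen atom. A methylamino link or a methylene link at this place, each carrying the same phenyl ring, would help to tell these two apart.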